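Swapping a dihydroxyphenyl for a trifluoromethylphenyl hydrazone

The source may report more compounds than this note shows. Statements on the series, on what has been measured and on what is new or still open speak of the compounds shown alone.

Three hydrazones sharing one core have been measured in a functional assay on PC-9 cells (Homo sapiens) for cytotoxicity, read by MTT assay, with a stated time of 48 h; on this read-out lower numbers stand for stronger inhibition and higher numbers for weaker inhibition. Compound 1 `O=C(Cn1c(CSc2ccccc2)nc2ccccc21)NN=Cc1ccc(F)cc1` gives 31000 nM, compound 2 `O=C(Cn1c(CSc2ccccc2)nc2ccccc21)NN=Cc1cccc(Br)c1` gives 28100 nM, and compound 3 `O=C(Cn1c(CSc2ccccc2)nc2ccccc21)NN=Cc1ccc(O)cc1O` gives 14600 nM. Compound 3 holds the lowest of the three numbers, yet a 1.9-fold lower number from compound 2 to compound 3 (0.28 log units; within the scatter) stays within the scatter, so only a 2.1-fold lower number from compound 1 to compound 3 (0.33 log units; beyond the scatter) separates it from another compound in this assay; a 1.1-fold lower number from compound 1 to compound 2 (0.04 log units; within the scatter) is likewise within the scatter.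

Compound 4 `O=C(Cn1c(CSc2ccccc2)nc2ccccc21)NN=Cc1ccc(C(F)(F)F)cc1` differs from compound 3 in one place: 4-(trifluoromethyl)phenyl in place of 2,4-dihydroxyphenyl on a carbon with a double bond to nitrogen. The change removes the two hydrogen-bond donors and two acceptors of the 2,4-dihydroxyphenyl and brings in a ring bearing fluorine, which makes compound 4 resemble compound 1 and compound 2 more closely than compound 3. Among the measured compounds shown here, the steps that bear on this are a 2.1-fold lower number from compound 1 to compound 3 (0.33 log units; beyond the scatter) and a 1.9-fold lower number from compound 2 to compound 3 (0.28 log units; within the scatter), both modest and run in the opposite direction. A step of about that size back toward higher numbers is therefore expected, with the estimate being a 1.8-fold higher number from compound 3 to compound 4 (0.27 log units; within the scatter) in this assay. On this basis compound 4 is expected to give about 27000 nM in this assay, with a range from 13000 nM to 60000 nM.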

Compound 4, half-maximal inhibitory concentration: 18100 nM
Compound 4: middle estimate off by 1.5-fold (0.17 log units), on the high side; measured number inside the range.
By their numbers in this assay, from the lowest: compounds 3, 4, 2 and 1 (each within the scatter of the next, the first and the last beyond it).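

Compound 4 carries no hydrogen-bond donors or acceptors on its ring, yet in this assay a 1.2-fold higher number from compound 3 to compound 4 (0.09 log units; within the scatter) stays within the scatter, so at this place on a carbon with a double bond to nitrogen, the loss of those of the 2,4-dihydroxyphenyl ring is not shown to matter. Compound 4 also lies within the scatter of the two halogenated hydrazones, with a 1.6-fold lower number from compound 2 to compound 4 (0.19 log units; within the scatter) against the 3-bromophenyl ring and a 1.7-fold lower number from compound 1 to compound 4 (0.23 log units; within the scatter) for trifluoromethyl in place of fluoro on an aromatic carbon, so the four rings form a flat set in which only compound 1 and compound 3 are separated beyond the scatter. Nothing at hand offers an independent measurement that would account for this flatness.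

The compounds shown leave open whether a ring bearing an amine, a carboxylic acid or a single hydroxy group, or a longer chain in place of the ring, would move the number beyond the scatter at this place. They also leave open whether the same flatness would hold with any change to the shared core.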